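Swapping the Pyrazine for a Chloropyridine in Compound 3

This account rests on a few compounds, and the source may have more. Where it says the series, first, only, none or still open, it means among the compounds named here.

Measured so far:
compound 1 `C[C@@H](NC(=O)C1(NC(=O)c2ccc(Br)nc2)CC1)c1ccc(-n2nc(Cl)c3ccccc32)cc1F` – 2.6 mL/min/kg
compound 2 `C[C@@H](NC(=O)C1(NC(=O)c2cncc(Cl)n2)CC1)c1ccc(-n2nc(Cl)c3ccccc32)cc1F` – 10.5 mL/min/kg

In an in vivo ADME assay on the whole organism (strain Mongrel) for pharmacokinetics, with Canis familiaris (Canis lupus familiaris) as the target (on this read-out lower numbers stand for slow clearance and higher numbers for fast clearance), compound 2 gives the highest of the two numbers, with compound 1 the nearer one and the only other, a 4.0-fold higher number from compound 1 to compound 2 (0.61 log units; beyond the scatter). Compound 3 `C[C@@H](NC(=O)C1(NC(=O)c2cncc(Cl)c2)CC1)c1ccc(-n2nc(Cl)c3ccccc32)cc1F` differs from compound 2 by 5-chloropyridin-3-yl in place of 6-chloropyrazin-2-yl on a carbonyl carbon. Within the data shown here, only that single step bears on this change, and it was modest. Since compound 1, which also carries a pyridine, gave 2.6 mL/min/kg, compound 3 is expected to show a lower number, a 2.1-fold lower number from compound 2 to compound 3 (0.32 log units; beyond the scatter). Compound 3 is therefore estimated at 5 mL/min/kg in this assay, within 2.5 mL/min/kg to 11 mL/min/kg.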

Compound 3, clearance: 3.1 mL/min/kg
Estimate against measurement, compound 3: 1.6-fold (0.21 log units) above, and the stated range covers the measured number.
By their numbers in this assay, from the lowest: compounds 1 and 3 (each within the scatter of the next); then compound 2.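

In this assay, the 5-chloropyridin-3-yl group in place of 6-chloropyrazin-2-yl on a carbonyl carbon gives a 3.4-fold lower number from compound 2 to compound 3 (0.53 log units; beyond the scatter) and so keeps the chlorine while changing only the ring. The two pyridine compounds are not told apart, with a 1.2-fold higher number from compound 1 to compound 3 (0.08 log units; within the scatter) between them, so among these three compounds only the pyrazine in compound 2 stands apart from the others. What the compounds shown leave open is whether a pyridine carrying an amine or a methoxy group instead of the halogen would stay this low. No measurement offered here accounts for the difference between the rings.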